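Triazole aryl variation on a terpenoid ester in DU-145 cells

The compounds below may be only part of what the source reports. "The series", "measured", "known", "first", "only" and "open" are said of these compounds alone.

Measured compounds:
- compound 1, `C/C(=C\CC/C(C)=C/CC[C@@H]1[C@@]2(C)CCC(=O)C(C)(C)[C@H]2CC[C@@]1(C)O)CC/C=C(\C)C(=O)OCc1cn(-c2ccc([N+](=O)[O-])cc2)nn1`, giving > 150000 nM
- compound 2, `C/C(=C\CC/C(C)=C/CC[C@@H]1[C@@]2(C)CCC(=O)C(C)(C)[C@H]2CC[C@@]1(C)O)CC/C=C(\C)C(=O)OCc1cn(-c2ccc(F)cc2)nn1`, giving > 150000 nM
- compound 3, `C/C(=C\CC/C(C)=C/CC[C@@H]1[C@@]2(C)CCC(=O)C(C)(C)[C@H]2CC[C@@]1(C)O)CC/C=C(\C)C(=O)OCc1cn(-c2ccccc2F)nn1`, giving > 150000 nM

In a functional assay on DU-145 cells (Homo sapiens) for antiproliferative activity, read by MTT assay, with a stated time of 48 h (on this read-out lower numbers stand for stronger inhibition and higher numbers for weaker inhibition), compound 1 gives > 150000 nM, which is a limit of the assay rather than a number. Compound 2 also gives a limit in this assay, > 150000 nM. Compound 3 likewise gives a limit, > 150000 nM. Because all three values sit at the limit of > 150000 nM in this assay, at which 3 of the 3 values shown sit, the step from compound 1 to compound 2 is a step that the two limits leave unreadable from compound 1 to compound 2, the step from compound 1 to compound 3 is a step that the two limits leave unreadable from compound 1 to compound 3, and the step from compound 2 to compound 3 is a step that the two limits leave unreadable from compound 2 to compound 3; none of them can be read.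

Compound 4, `C/C(=C\CC/C(C)=C/CC[C@@H]1[C@@]2(C)CCC(=O)C(C)(C)[C@H]2CC[C@@]1(C)O)CC/C=C(\C)C(=O)OCc1cn(-c2cccc([N+](=O)[O-])c2)nn1`, has not been measured. It differs from compound 1 by 3-nitrophenyl in place of 4-nitrophenyl on an aromatic nitrogen. The steps that bear on this change, the three described above, are all unreadable, so no direction or size can be drawn from them; the only indication is that every aryl variation so far left the value at the limit. The expected step from compound 1 to compound 4 is therefore a step that the limit leaves unreadable from compound 1 to compound 4. Compound 4 is estimated at 200000 nM, with a range from 100000 nM to 400000 nM, and most likely reported again only as a limit.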

Compound 4, half-maximal inhibitory concentration: > 150000 nM
Compound 4: only a limit was reported; the forecaster's own chance of this, stated with the estimate: 85%; the middle value lies beyond the limit too.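

In this assay compound 4 gives > 150000 nM, again a limit and not a number. Its steps from compound 1, compound 2 and compound 3 therefore cannot be read: the limit of > 150000 nM in this assay, at which 4 of the 4 values shown sit.

Going by these compounds, whether any of these aryl groups changes the activity of the shared core, and in which direction, stays open.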